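A Different Aryl Group on the Ring Nitrogen

The source may hold more compounds than are shown below. What is called first, only, known or untested is meant among the compounds shown, and "the series" means these compounds.

Compound 1 `CCCc1nc(-c2ccccc2)c(CNCCN2CCN(c3ccc(Cl)cc3)CC2)o1`: 55.8%
Compound 2 `CCCc1nc(-c2ccccc2)c(CNCCN2CCN(c3cccc(C(F)(F)F)c3)CC2)o1`: 56.3%
Compound 3 `CCCc1nc(-c2ccccc2)c(CNCCCN2CCN(c3ccccc3C(F)(F)F)CC2)o1`: 45%

All three share one core and differ in the aryl group on an amine nitrogen in a ring and in the chain leading to it. In an assay on HEK293 cells for inhibition of Voltage-dependent T-type calcium channel subunit alpha-1G (Homo sapiens), read by fluorescence, tested at 10 uM (a lower number here means less inhibition, a higher number more inhibition at the concentration tested (going by the name of the read-out)), compound 3 gives the lowest number of the three, beyond the scatter under both compound 1 and compound 2. Compound 4 `CCCc1nc(-c2ccccc2)c(CNCCCN2CCN(c3ccc(C)c(C)c3)CC2)o1` differs from compound 3 in one place: 3,4-dimethylphenyl in place of 2-(trifluoromethyl)phenyl on an amine nitrogen in a ring. Among the measured compounds shown here, the only measured step that bears on such a change, a number 0.5 percentage points higher from compound 1 to compound 2 (within the scatter), also swapped the aryl group on that ring nitrogen and stayed within the scatter. A similarly small step with no clear direction is therefore expected, so compound 4 is estimated at 48% in this assay, between 35% and 62%, a step of a number 3 percentage points higher from compound 3 to compound 4 (within the scatter).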

Compound 4, a percentage reported as inhibition, at one concentration (the size of the read-out at that concentration, not a potency): 54.6%
Estimate against measurement, compound 4: 6.6 percentage points below; the range from low to high includes it.
By their numbers in this assay, from the lowest: compounds 3, 4, 1 and 2 (each within the scatter of the next, the first and the last beyond it).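

In this assay, putting 3,4-dimethylphenyl on the ring nitrogen in place of 2-(trifluoromethyl)phenyl, with the chain unchanged, gives a number 9.6 percentage points higher from compound 3 to compound 4 (within the scatter). This is a second aryl swap at this position that stays within the scatter, now on a different chain from compound 1 and compound 2, and with all three fluorine atoms gone. Nothing available explains this small step. On these data alone, what remains open is how this position would respond to an aryl ring carrying an amine or a carboxylic acid.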